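Adding a chloro group beside the ring nitrogen of compound 1

The source may hold more compounds than are shown below. What is called first, only, known or untested is meant among the compounds shown, and "the series" means these compounds.

Measured compounds:
compound 1 `Brc1cncc(OC[C@@H]2CCN2)c1` 0.18 nM
compound 2 `Cc1cncc(OC[C@@H]2CCN2)c1` 0.047 nM
compound 3 `c1ccc(-c2cncc(OC[C@@H]3CCN3)c2)cc1` 0.046 nM

In an assay on brain for binding affinity to Neuronal acetylcholine receptor; alpha4/beta2 (Rattus norvegicus), read by radioligand binding (on this read-out higher numbers stand for weaker inhibition and lower numbers for stronger inhibition), compound 1 gives the highest number of the three, beyond the scatter from compound 2 a 3.8-fold lower number from compound 1 to compound 2 (0.58 log units; beyond the scatter) and from compound 3 a 3.9-fold lower number from compound 1 to compound 3 (0.59 log units; beyond the scatter); compounds 2 and 3 lie within the scatter of each other a 1.0-fold lower number from compound 2 to compound 3 (0.01 log units; within the scatter). Compound 4 `Clc1ncc(OC[C@@H]2CCN2)cc1Br` differs from compound 1 by chloro in place of hydrogen on an aromatic carbon: next to the ring nitrogen, ortho to the bromo group. For the measured compounds named here, no measured step adds a group at this place; all three replace the bromo itself, so they give no direct guidance. The bromo group is kept, so compound 4 is expected near compound 1, a step of no change at the digits printed from compound 1 to compound 4 (within the scatter) not clearly beyond the scatter. The estimate for compound 4 is 0.18 nM, between 0.04 nM and 0.8 nM.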

Compound 4, inhibition constant: 0.015 nM
Compound 4: middle estimate off by 12-fold (1.08 log units), on the high side, and the stated range ends above it.
By their numbers in this assay, from the lowest: compound 4; then compounds 3 and 2 (each within the scatter of the next); then compound 1.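

The earlier steps shown here only replaced the bromo group itself, and this one shows that the core of compound 1 also responds to a group added elsewhere, on the aromatic carbon next to the ring nitrogen. In this assay, chloro in place of hydrogen there, with the bromo group kept, gives a 12-fold lower number from compound 1 to compound 4 (1.08 log units; beyond the scatter) and so counts as large, while the replacements of the bromo group were modest. No measurement shown here explains this change.

Going by these compounds, it remains open whether a fluoro or methoxy group at this place would give a similar step. On these data alone, it is also open whether chloro here would act the same way with the methyl group of compound 2 or the phenyl group of compound 3 in place of the bromo group.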